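From methoxy to ethoxy at the assay limit

The source may report more compounds than this note shows. Statements on the series, on what has been measured and on what is new or still open speak of the compounds shown alone.

Compound 1 `COc1cc(-n2ncnc2-c2ccccc2)cc(OC)c1OC`: > 10000 nM, a limit
Compound 2 `COc1ccccc1-c1ncnn1-c1cc(OC)c(OC)c(OC)c1`: > 10000 nM, a limit

Both compounds were tested in a functional assay on K562 cells (Homo sapiens) for antiproliferative activity, read by MTT assay, with a stated time of 72 h; on this read-out higher numbers stand for weaker inhibition and lower numbers for stronger inhibition. Compound 2 stands at the limit of > 10000 nM in this assay, at which 2 of the 2 values shown sit, so it offers a limit and no number. Compound 3 `CCOc1ccccc1-c1ncnn1-c1cc(OC)c(OC)c(OC)c1` changes its methoxy to ethoxy, with methyl in place of hydrogen on a saturated chain carbon bound to an oxygen on an aromatic ring. Among the measured compounds shown here, the one measured step that bears on this is a step that the two limits leave unreadable from compound 1 to compound 2, with methoxy in place of hydrogen on an aromatic carbon. That step gives no size to carry over, so no change beyond the scatter is expected in this assay, and no direction can be named. The expected step is a step that the limit leaves unreadable from compound 2 to compound 3. Another limit is the likeliest report. Compound 3 is estimated at 15000 nM, with an expected range from 6000 nM to 40000 nM.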

Compound 3, half-maximal inhibitory concentration: > 10000 nM
Compound 3: a limit, no number (the forecaster's own chance of this, stated with the estimate: 80%); the middle value does not contradict the limit.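

No step can be read between compound 1, compound 2 and compound 3, because each gives a limit and no number: the limit of > 10000 nM in this assay, at which 3 of the 3 values shown sit.

In this assay the compounds shown leave open whether hydrogen, methoxy or ethoxy on the shared core makes any difference to the result.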